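This account rests on a few compounds, and the source may have more. Where it says the series, first, only, none or still open, it means among the compounds named here.

Working notes on the series. Compound 1 `COc1ccccc1C(=O)NCCNc1cccc(NS(=O)(=O)c2cc(-c3ccccc3)ccc2OC)c1` and compound 2 `COc1cccc(-c2ccc(OC)c(S(=O)(=O)Nc3cccc(NCCNC(=O)c4ccccc4OC)c3)c2)c1` share one core. In an assay on CHO-K1 cells for agonist activity at Orexin receptor type 2 (Homo sapiens), read by a luciferase reporter (a lower number here means that less compound is needed, a higher number that more compound is needed for the effect), compound 1 gives only a limit of the assay, > 10000 nM. In this assay compound 2 gives 800 nM. The change between them is methoxy in place of hydrogen on an aromatic carbon, and it brings an at least 12-fold lower number from compound 1 to compound 2 (1.09 log units; beyond the scatter). Compound 3 `COc1ccc(-c2cccc(C(=O)N(C)C)c2)cc1S(=O)(=O)Nc1cccc(NCCNC(=O)c2ccccc2)c1` sits on a different core; the difference between the two cores is not broken down here. In this assay compound 3 gives only a limit of the assay, > 10000 nM. Compound 4 `COc1cccc(C(=O)NCCNc2cccc(NS(=O)(=O)c3cc(-c4cccc(C(=O)N(C)C)c4)ccc3OC)c2)c1` differs from compound 3 by methoxy in place of hydrogen on an aromatic carbon. The place is the same word for word as in the earlier pair, so this is the same change, made a second time on the other core. One caution stands out: the limit of > 10000 nM in this assay, at which 2 of the 3 values shown sit, so the earlier step starts from a limit and its true size is open-ended, and the new step starts from a limit as well. For compound 4 a step of about an at least 5.0-fold lower number from compound 3 to compound 4 (0.69 log units; beyond the scatter) is expected, resting on the earlier step of an at least 12-fold lower number from compound 1 to compound 2 (1.09 log units; beyond the scatter). Compound 4 is therefore estimated at around 2000 nM, with a range from 500 nM to 10000 nM, and with a real chance that this assay again reports only a limit for compound 4, as it does for compound 3.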

Compound 4, half-maximal effective concentration: 33 nM
Beside the measured number, compound 4's estimate is 61-fold (1.78 log units) above it; measured number below the stated range.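

In this assay, methoxy in place of hydrogen on an aromatic carbon gives an at least 300-fold lower number from compound 3 to compound 4 (2.48 log units; beyond the scatter), so the change that lowered the number on the core of compound 1 lowers it on the core of compound 3 as well. The direction therefore carries over between these two cores, but no difference in size between the two steps can be claimed: the same change on two cores in this assay, an at least 12-fold lower number (1.09 log units; beyond the scatter) from compound 1 to compound 2 and an at least 300-fold lower number (2.48 log units; beyond the scatter) from compound 3 to compound 4; the limit leaves it open whether they differ. Each step starts from a limit of the assay, so each size is only a minimum, and two pairs give no rule for any further core: the limit of > 10000 nM in this assay, at which 2 of the 4 values shown sit.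

The compounds shown leave open whether a longer chain such as ethoxy, a hydroxyl group or a fluorine atom in place of the methoxy would bring a step of the same kind. They also leave open whether the step on the core of compound 3 would survive an amine or a carboxylic acid in place of the dimethylamide group on that core.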